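Propyl to 3-Hydroxypropyl on a Pair Without Numbers

The source may hold more compounds than are shown below. What is called first, only, known or untested is meant among the compounds shown, and "the series" means these compounds.

Compound 1 `CCCNc1nc(/C=C/c2ccc(OC)c(OC)c2)cc(/C=C/c2ccc(OC)c(OC)c2)n1` — > 100000 nM
Compound 2 `CCCNc1nc(/C=C/c2cc(OC)c(OC)c(OC)c2)cc(/C=C/c2cc(OC)c(OC)c(OC)c2)n1` — > 100000 nM

Of the compounds shown here, two have been measured in a functional assay on HT-29 cells (Homo sapiens) for inhibition, read by resazurin assay, with a stated time of 48 h (on this read-out lower numbers stand for stronger inhibition and higher numbers for weaker inhibition), and neither returned a number. In this assay compound 1 reaches only a limit, > 100000 nM. Compound 2 likewise reaches only a limit in this assay, > 100000 nM. Where compound 2 stands is therefore known from one side alone: it sits at the limit of > 100000 nM in this assay, at which 2 of the 2 values shown sit, and no value beneath that boundary has been resolved for it. Both values shown are limits. Going by the values given here, no step between measured compounds can be stated in size or direction.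

Compound 3 `COc1cc(/C=C/c2cc(/C=C/c3cc(OC)c(OC)c(OC)c3)nc(NCCCO)n2)cc(OC)c1OC` is the next member to be tested. It differs from compound 2 by hydroxy in place of hydrogen on a saturated chain carbon, three bonds along the chain from a nitrogen on an aromatic ring. Among the compounds with values here, with compound 2 itself recorded only as a limit, there is no measured pair from which the effect of this change could be read, and the account rests on the structural change alone.

Compound 3 is expected to give 100000 nM in this assay, within 30000 nM to 300000 nM, and most likely to be reported again as a limit. The step of a number no higher from compound 2 to compound 3 (the limit leaves the size open) is expected to be none beyond the scatter.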

Compound 3, half-maximal inhibitory concentration: 12400 nM
Compound 3: middle estimate off by 8.1-fold (0.91 log units), on the high side, and the stated range ends above it.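

In this assay, going by these compounds alone, the change from propyl to 3-hydroxypropyl gives an at least 8.0-fold lower number from compound 2 to compound 3 (0.90 log units; beyond the scatter), the first step that can be stated at all. Compound 3 is also the first compound shown to return a number rather than a limit, so this position, on a saturated chain carbon, three bonds along the chain from a nitrogen on an aromatic ring, is one where a single added hydroxy is enough to bring a measurable value within reach of the assay. The step has a lower bound only, and its full size stays unknown, since its starting point is a limit: the limit of > 100000 nM in this assay, at which 2 of the 3 values shown sit.

What the compounds shown leave open is whether this gain belongs to the hydroxy itself or would also appear with an amine, a carboxylic acid, a methoxy or a longer chain ending in hydroxy at the same place. They also leave open whether the same change would bring a number on the core of compound 1, and this single pair gives no reason for the step, which rests on one change in one cell line.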